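Taking a Methoxy Group Off Two Different Cores

The compounds below may be only part of what the source reports. "The series", "measured", "known", "first", "only" and "open" are said of these compounds alone.

Compound 1 `COc1cc(C(=O)NNC(=S)Nc2csc(-c3ccc(C)cc3)c2)cc(OC)c1OC` and compound 2 `COc1cc(OC)cc(C(=O)NNC(=S)Nc2csc(-c3ccc(C)cc3)c2)c1` share one core, and compound 3 `COc1ccc(-c2cc(Nc3nnc(-c4ccc(C)cc4)s3)cs2)cc1` and compound 4 `Cc1ccc(-c2nnc(Nc3csc(-c4ccccc4)c3)s2)cc1` share another; the difference between the two cores is not broken down here. In a functional assay on SK-MEL-28 cells (Homo sapiens) for inhibition, read by colorimetric assay and MTT assay, with a stated time of 72 h (a lower number here means a stronger inhibitor, a higher number a weaker inhibitor), compound 1 gives 42000 nM and compound 2 gives 38000 nM. The change between them, (hydrogen in place of methoxy on an aromatic carbon), gave a 1.1-fold lower number from compound 1 to compound 2 (0.04 log units; within the scatter). For compound 3 the assay reports only a limit, > 100000 nM, at which (the limit of > 100000 nM in this assay, at which 1 of the 3 values shown sits). The change from compound 3 to compound 4, (hydrogen in place of methoxy on an aromatic carbon), is the same kind of change, but its surroundings differ: in compound 1 the carbon is ortho to two methoxy groups (2 heavy atoms each) and para to a large group, whereas in compound 3 it is only para to a large group. Since compound 3 sits at the limit and the measured step of a 1.1-fold lower number from compound 1 to compound 2 (0.04 log units; within the scatter) was within the scatter, compound 4 is expected to remain near that limit, with an expected step that the limit leaves unreadable from compound 3 to compound 4. Compound 4 is estimated at 120000 nM, between 40000 nM and 400000 nM.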

Compound 4, half-maximal inhibitory concentration: > 100000 nM
Compound 4: a limit, no number; the forecaster's own chance of this, stated with the estimate: 70%; the middle value does not contradict the limit.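

Compound 4 gives > 100000 nM in this assay, which is a limit and not a number. Within the data shown here, compound 3 also has only a limit, so no step between compound 3 and compound 4 can be read: the limit of > 100000 nM in this assay, at which 2 of the 4 values shown sit. The compounds shown leave open whether replacing methoxy with hydrogen on this core changes the value at all.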